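This account rests on a few compounds, and the source may have more. Where it says the series, first, only, none or still open, it means among the compounds named here.

Measured so far in a functional assay on A-375 cells (Homo sapiens) for cytotoxicity, read by MTT assay, with a stated time of 72 h; a lower number here means a stronger inhibitor, a higher number a weaker inhibitor:
compound 1 `O=C1c2c[n+]([O-])c3ccccc3c2C(=O)c2c1c1ccccc1n2Cc1cn(C[C@@H](O)CO)nn1`: 140 nM
compound 2 `CC1(C)O[C@@H](CO)[C@H](Cn2cc(Cn3c4c(c5ccccc53)C(=O)c3c[n+]([O-])c5ccccc5c3C4=O)nn2)O1`: 190 nM

Compound 1 gives the lower of the two numbers shown, though the step of a 1.4-fold higher number from compound 1 to compound 2 (0.13 log units; within the scatter) lies within the scatter, so the two compounds cannot be ordered. Compound 3 `O=C1c2c[n+]([O-])c3ccccc3c2C(=O)c2c1c1ccccc1n2CCCCN1CCNCC1` differs from compound 1 in one place: 3-(piperazin-1-yl)propyl in place of 1-(2,3-dihydroxypropyl)-1H-1,2,3-triazol-4-yl on a saturated chain carbon bound to an aromatic nitrogen. Among the measured compounds shown here, the only measured step, from compound 1 to compound 2, alters the chain but keeps the triazole, and it was small. For the measured compounds named here, no measured step removes the triazole, so the present change is untested. A modest step is expected, a 1.6-fold higher number from compound 1 to compound 3 (0.20 log units; within the scatter). Compound 3 is therefore estimated at 220 nM, expected between 70 nM and 700 nM.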

Compound 3, half-maximal inhibitory concentration: 460 nM
Compound 3: middle estimate off by 2.1-fold (0.32 log units), on the low side; measured number inside the range.
By their numbers in this assay, from the lowest: compounds 1 and 2 (each within the scatter of the next); then compound 3.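

In this assay, the step to 3-(piperazin-1-yl)propyl gives a 3.3-fold higher number from compound 1 to compound 3 (0.52 log units; beyond the scatter). This place, on a saturated chain carbon bound to an aromatic nitrogen, therefore responds beyond the scatter once the 1-(2,3-dihydroxypropyl)-1H-1,2,3-triazol-4-yl group is replaced, which the earlier step, keeping the triazole, did not show. No evidence at hand accounts for this difference.

As far as these compounds go, the triazole and the piperazine changed in a single step, so their separate contributions remain open. A morpholine on the same propyl chain, or a piperazine attached to the triazole, would bear on that question.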